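A few compounds are considered here, and "the series" means these few. Any claim that something is new, unique, unknown or untested is made for them only; others in the source may bear on it.

Of the compounds shown here, three built on one shared core have been measured in an assay on isolated protein for inhibition of histone deacetylase 4 (Homo sapiens), with a stated time of 1 h; on this read-out lower numbers stand for stronger inhibition and higher numbers for weaker inhibition. Compound 1 `O=C(COc1ccc2cc(/C=C3/SC(=O)NC3=O)ccc2c1)Nc1ccc(Br)cc1F` gives 1900 nM. Compound 2 `COc1cccc(NC(=O)COc2ccc3cc(/C=C4/SC(=O)NC4=O)ccc3c2)c1` gives 1600 nM, and compound 3 `O=C(COc1ccc2cc(/C=C3/SC(=O)NC3=O)ccc2c1)Nc1ccc(F)cc1` gives 1600 nM. Compound 2 thus stands level with compound 3, the two together the lowest of the three numbers, with compound 1 close by. Every step among them alters the group on the amide-type nitrogen: a 1.2-fold lower number from compound 1 to compound 2 (0.07 log units; within the scatter), a 1.2-fold lower number from compound 1 to compound 3 (0.07 log units; within the scatter) and no change at the digits printed from compound 2 to compound 3 (within the scatter), each within the scatter. Compound 4 `Cc1cc(NC(=O)COc2ccc3cc(/C=C4/SC(=O)NC4=O)ccc3c2)no1` alters that same group once more: 5-methyl-1,2-oxazol-3-yl in place of 3-methoxyphenyl on an amide-type nitrogen. Because no change at the digits printed from compound 2 to compound 3 (within the scatter) and the other two steps at this nitrogen stayed within the scatter, a similarly small step is expected here: a 1.1-fold higher number from compound 2 to compound 4 (0.05 log units; within the scatter). Compound 4 is therefore estimated at 1800 nM, within a range from 700 nM to 4500 nM.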

Compound 4, half-maximal inhibitory concentration: 1700 nM
Beside the measured number, compound 4's estimate is 1.1-fold (0.02 log units) above it, within the range that was stated.
By their numbers in this assay, from the lowest: compounds 2, 3, 4 and 1 (each within the scatter of the next).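

Until now, every group on this amide-type nitrogen carried a six-membered aromatic ring of carbon only, whereas 5-methyl-1,2-oxazol-3-yl brings a five-membered aromatic ring with 2 hetero atoms and fewer heavy atoms. Even so, this assay shows a 1.1-fold higher number from compound 2 to compound 4 (0.03 log units; within the scatter) and a 1.1-fold higher number from compound 3 to compound 4 (0.03 log units; within the scatter) and also a 1.1-fold lower number from compound 1 to compound 4 (0.05 log units; within the scatter) with all three steps within the scatter, so this change of ring leaves the number effectively unmoved. No evidence is at hand to explain this. The compounds shown leave open whether an open ethyl chain, an amine or a carboxylic acid on this nitrogen would read the same.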